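The source may hold more compounds than are shown below. What is called first, only, known or untested is meant among the compounds shown, and "the series" means these compounds.

Working notes on the benzyl ether series. Compound 1 `N#Cc1ccccc1COc1c(-c2ccccc2)oc2cc(O)cc(O)c2c1=O` gives in an ADME assay on Huh-5-2 cells (Homo sapiens) for cytotoxicity, read by WST assay, with a stated time of 3 days (a lower number here means that less compound is tolerated, a higher number that more compound is tolerated), a value that is a limit of the assay, > 100000 nM (the limit of > 100000 nM in this assay, at which 1 of the 3 values shown sits). Compound 2 `O=c1c(OCc2ccccc2[N+](=O)[O-])c(-c2ccccc2)oc2cc(O)cc(O)c12` gives 51000 nM in this assay; the change is nitro in place of cyano on an aromatic carbon, and the step is an at least 1.9-fold lower number from compound 1 to compound 2 (0.29 log units; that floor lies within the scatter). Compound 3 `N#Cc1ccc(COc2c(-c3ccccc3)oc3cc(O)cc(O)c3c2=O)cc1` gives 48000 nM; its core differs from that of compound 1 by 4-cyanophenyl in place of 2-cyanophenyl on a saturated chain carbon bound to an oxygen on an aromatic ring, and the two measured values read an at least 2.0-fold lower number from compound 1 to compound 3 (0.31 log units; beyond the scatter) and a 1.1-fold lower number from compound 2 to compound 3 (0.03 log units; within the scatter). Compound 4 `O=c1c(OCc2ccc([N+](=O)[O-])cc2)c(-c2ccccc2)oc2cc(O)cc(O)c12` is not yet measured. It differs from compound 3 by nitro in place of cyano on an aromatic carbon; this is the same kind of change as from compound 1 to compound 2, the place differing in that the group sits para to a large group rather than ortho to a large group. The earlier step of an at least 1.9-fold lower number from compound 1 to compound 2 (0.29 log units; that floor lies within the scatter) has a floor within the scatter, so only a modest shift is expected for compound 4, a 1.4-fold lower number from compound 3 to compound 4 (0.14 log units; within the scatter). Compound 4 is estimated at 35000 nM, between 15000 nM and 80000 nM.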

Compound 4, half-maximal cytotoxic concentration: 40000 nM
Compound 4: middle estimate off by 1.1-fold (0.06 log units), on the low side; low and high end bracket the measured number.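

Nitro in place of cyano on an aromatic carbon has now been read on two cores in this assay: the same change on two cores in this assay, an at least 1.9-fold lower number (0.29 log units; that floor lies within the scatter) from compound 1 to compound 2 and a 1.2-fold lower number (0.08 log units; within the scatter) from compound 3 to compound 4; the limit leaves it open whether they differ

On the core of compound 3 the change gives a 1.2-fold lower number from compound 3 to compound 4 (0.08 log units; within the scatter), so no shift is shown there, and moving the nitro group gives a 1.3-fold lower number from compound 2 to compound 4 (0.11 log units; within the scatter). The step of an at least 2.5-fold lower number from compound 1 to compound 4 (0.39 log units; beyond the scatter) starts from a limit, which leaves its true size unknown, and carrying the change across cores is neither confirmed nor ruled out: the limit of > 100000 nM in this assay, at which 1 of the 4 values shown sits.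

The compounds shown leave open how an amine or a carboxylic acid in place of cyano or nitro would read. Going by these compounds, a longer chain in place of the single saturated carbon on the ether oxygen also remains open.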